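Swapping an Anilide Ring Ahead of a Cytotoxicity Test

The source may hold more compounds than are shown below. What is called first, only, known or untested is meant among the compounds shown, and "the series" means these compounds.

Compound 1 `COc1cc2nc(Nc3ccc(C#N)cc3)nc(Nc3c(F)cc(/C=C/C#N)cc3F)c2cc1OC`: 6400 nM
Compound 2 `COc1cc2nc(SCC(=O)Nc3ccc(C(F)(F)F)cc3)nc(Nc3c(Cl)cc(/C=C/C#N)cc3Cl)c2cc1OC`: > 197000 nM
Compound 3 `COc1cc2nc([S+]([O-])CC(=O)Nc3ccc([N+](=O)[O-])cc3)nc(Nc3c(Cl)cc(/C=C/C#N)cc3Cl)c2cc1OC`: 92800 nM

Of the compounds shown here, three on a shared core have been tested in an ADME assay on MT4 cells (Homo sapiens) for cytotoxicity, read by MTT assay, with a stated time of 5 days; on this read-out higher numbers stand for lower toxicity in this test and lower numbers for higher toxicity in this test. Compound 1 gives 6400 nM. Compound 2 sits at the limit of the test, > 197000 nM, so no number is known for it. Compound 3 gives 92800 nM, the higher of the two numbers, and its gap from compound 1 lies beyond the usual scatter. Compound 4 `COc1cc2nc([S+]([O-])CC(=O)Nc3c(C)cc(C)cc3C)nc(Nc3c(Cl)cc(/C=C/C#N)cc3Cl)c2cc1OC` awaits measurement. It differs from compound 3 in one place: 2,4,6-trimethylphenyl in place of 4-nitrophenyl on an amide-type nitrogen. Among the compounds with values here, no measured pair differs by this change alone, so no step is known for it. In this assay the step of a 1.1-fold higher number from compound 3 to compound 4 (0.03 log units; within the scatter) is expected to stay within the scatter. Compound 4 is therefore expected to give about 100000 nM, between 40000 nM and 250000 nM.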

Compound 4, half-maximal cytotoxic concentration: 8870 nM
Estimate against measurement, compound 4: 11-fold (1.05 log units) above, outside the stated range (below it).
By their numbers in this assay, from the lowest: compounds 1 and 4 (each within the scatter of the next); then compound 3. At a limit, above all of these: compound 2.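

With the shared core held fixed, the aryl ring on this amide-type nitrogen proves able to move the result on its own: in this assay, 2,4,6-trimethylphenyl in place of 4-nitrophenyl gives a 10-fold lower number from compound 3 to compound 4 (1.02 log units; beyond the scatter), so toxicity in this test rises. The earlier compounds shown here offered no pair differing in one place, so they could not show this. Nothing measured here accounts for the size of this step.

From the compounds shown here alone, this one change removes the nitro group and adds three methyl groups together, and which of these carries the step stays open. A plain phenyl ring on that nitrogen, carrying neither, lies outside the compounds shown.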